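A few compounds are considered here, and "the series" means these few. Any claim that something is new, unique, unknown or untested is made for them only; others in the source may bear on it.

Measured compounds in the series:

Compound 1, `CC(C)[C@H](NC(=S)Nc1ccccc1)c1nc2ccccc2[nH]1`: 5200 nM
Compound 2, `CC(C)C[C@H](NC(=S)Nc1ccccc1)c1nc2ccccc2[nH]1`: 28600 nM
Compound 3, `CC(C)C[C@@H](NC(=S)Nc1cc(C(F)(F)F)cc(C(F)(F)F)c1)c1nc2ccccc2[nH]1`: 10200 nM

All values come from a functional assay on A549 cells (Homo sapiens) for cytotoxicity, read by MTT assay; a higher number here means a weaker inhibitor, a lower number a stronger inhibitor. Compound 2 and compound 1 share a core and differ in one place: isopropyl in place of isobutyl on a saturated chain carbon bound to an amide-type nitrogen and an aromatic carbon. That change gave a 5.5-fold lower number from compound 2 to compound 1 (0.74 log units; beyond the scatter). Compound 3 stands on a different core from compound 2; the difference between the two cores is not broken down here. Compound 3 and compound 1 lie within the usual scatter of each other, while compound 3 sits below compound 2 by a margin that is beyond it.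

Compound 4, `CC(C)[C@@H](NC(=S)Nc1cc(C(F)(F)F)cc(C(F)(F)F)c1)c1nc2ccccc2[nH]1`, has not yet been measured in this assay. It stands to compound 3 as compound 1 stands to compound 2: isopropyl in place of isobutyl on a saturated chain carbon bound to an amide-type nitrogen and an aromatic carbon. The change is the same in both pairs, at the same place. Going by the values given here, on the basis of compound 3 at 10200 nM and the step of a 5.5-fold lower number from compound 2 to compound 1 (0.74 log units; beyond the scatter), a step of similar direction is expected from compound 3 to compound 4, namely a 4.1-fold lower number from compound 3 to compound 4 (0.61 log units; beyond the scatter), with a wide range because the change has only one measured precedent. Compound 4 is therefore estimated at 2500 nM, between 800 nM and 8000 nM.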

Compound 4, half-maximal inhibitory concentration: 22400 nM
Compound 4: the middle estimate sits 9.0-fold (0.95 log units) below what was measured; measured number outside the range, above it.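

In this assay, isopropyl in place of isobutyl on the saturated chain carbon gives a 2.2-fold higher number from compound 3 to compound 4 (0.34 log units; beyond the scatter), which runs opposite to the earlier step on the core of compound 1. The two steps differ in direction and in size: the same change on two cores in this assay, a 5.5-fold lower number (0.74 log units; beyond the scatter) from compound 2 to compound 1 and a 2.2-fold higher number (0.34 log units; beyond the scatter) from compound 3 to compound 4, 12-fold (1.08 log units) apart, beyond the scatter of two such steps

In these two pairs, the result of the change therefore depends on the core, and a step read on one core cannot be carried to the other; what is not shown is which part of the difference between the cores is responsible, and two pairs give no rule for any further core.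

The compounds shown leave open whether a single trifluoromethyl group, or a nitrile or a methoxy group in place of the trifluoromethyl groups, would give a step closer to that from isobutyl to isopropyl on the core of compound 1. Also open, from the compounds shown here alone, is how a longer chain or a benzyl group at the same saturated chain carbon would read on each core.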